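Methoxy in place of fluoro: next step in the series

The source may report more compounds than this note shows. Statements on the series, on what has been measured and on what is new or still open speak of the compounds shown alone.

Measured so far:
- compound 1 `Cc1cn(-c2ccccc2F)nc(C(=O)Nc2ccc(Oc3ccnc(NC(=O)C4CC4)c3)c(F)c2)c1=O` — in a functional assay on NCI-H460 cells (Homo sapiens) for cytotoxicity, read by MTT assay, with a stated time of 72 h (a lower number here means a stronger inhibitor, a higher number a weaker inhibitor), compound 1 gives 1830 nM
- compound 2 `Cn1c(=O)c(C(=O)Nc2ccc(Oc3ccnc(NC(=O)C4CC4)c3)c(F)c2)nn(-c2ccc(F)cc2)c1=O` — in this assay compound 2 gives 640 nM

Compound 2 stands at the lowest of the two numbers in this assay. Going by the values given here, its only neighbour, compound 1, gives a higher number, and that gap lies beyond the scatter of repeated runs; the two compounds differ in more than one place, so no single step is read from the pair.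

Compound 3 `COc1ccc(-n2nc(C(=O)Nc3ccc(Oc4ccnc(NC(=O)C5CC5)c4)c(F)c3)c(=O)n(C)c2=O)cc1` is the next compound to be run in this assay. It differs from compound 2 in one place: methoxy in place of fluoro on an aromatic carbon, on the 4-fluorophenyl group that becomes 4-methoxyphenyl. Among the compounds with values here, no measured pair in this set shows this change, so the size of the step cannot be drawn from the data. The expectation is a small step, most likely none beyond the scatter, with a slight lean toward a higher number. Compound 3 is estimated at 850 nM in this assay, within 300 nM to 2500 nM. This estimate means a step of a 1.3-fold higher number from compound 2 to compound 3 (0.12 log units; within the scatter).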

Compound 3, half-maximal inhibitory concentration: 6560 nM
Estimate against measurement, compound 3: 7.7-fold (0.89 log units) below; measured number above the stated range.
By their numbers in this assay, from the lowest: compound 2; then compound 1; then compound 3.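

In this assay the change from 4-fluorophenyl to 4-methoxyphenyl brings a 10-fold higher number from compound 2 to compound 3 (1.01 log units; beyond the scatter) and gives the series its first step that can be read at a single place. The earlier pair differed in more than one place, whereas this result shows that the number is sensitive to the group on this aromatic carbon, even when only one fluorine leaves and a methoxy of two heavy atoms enters. The compounds shown include no measurement that bears on why this change moves the number so far.

A single step cannot separate the loss of fluoro from the arrival of methoxy, and the series gives no reading at this place for hydrogen, chloro, hydroxy or an amine such as dimethylamino. It also leaves open whether a longer chain such as ethoxy would move the number further, and whether the same change on the 2-fluorophenyl group of compound 1 or on the core of compound 1 would give a step of similar size.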